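The compounds below may be only part of what the source reports. "The series", "measured", "known", "first", "only" and "open" are said of these compounds alone.

In a functional assay on K562 cells (Homo sapiens) for inhibition, read by sulforhodamine B assay, with a stated time of 48 h, tested at 10 uM (a lower number here means less inhibition, a higher number more inhibition at the concentration tested (going by the name of the read-out)), compound 1 `Brc1cn2ccnc2c(-c2ccc3ncn(C4CCCCC4)c3c2)n1` gives 18% and compound 2 `Fc1ccccc1-c1cn2ccnc2c(-c2ccc3ncn(C4CCCCC4)c3c2)n1` gives 22.8%. Of the two numbers compound 2 holds the higher one, but the step of a number 4.8 percentage points higher from compound 1 to compound 2 (within the scatter) lies within the scatter, so the two compounds cannot be told apart on this read-out. Compound 3 `c1csc(-c2cn3ccnc3c(-c3ccc4ncn(C5CCCCC5)c4c3)n2)c1` differs from compound 2 by thiophen-2-yl in place of 2-fluorophenyl on an aromatic carbon. Within the data shown here, only one measured step bears on this change, the exchange of bromo for 2-fluorophenyl on an aromatic carbon, and it was small; no measured pair exchanges 2-fluorophenyl for thiophen-2-yl. Since the two measured compounds give close numbers, a step in this assay of a size beyond the scatter is not expected in either direction. Compound 3 is therefore expected to give about 22% in this assay, with a range from 8% to 38%. The step this estimate means, a number 0.8 percentage points lower from compound 2 to compound 3 (within the scatter), is expected to stay within the scatter.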

Compound 3, a percentage reported as inhibition, at one concentration (the size of the read-out at that concentration, not a potency): 27%
For compound 3 the middle estimate is 5 percentage points below the measured one, within the range that was stated.
By their numbers in this assay, from the lowest: compounds 1, 2 and 3 (each within the scatter of the next).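

In this assay, putting thiophen-2-yl in place of 2-fluorophenyl on this aromatic carbon gives a number 4.2 percentage points higher from compound 2 to compound 3 (within the scatter), so a five-membered aromatic ring with one hetero atom and a six-membered aromatic ring of carbon only cannot be told apart here. Against bromo, thiophen-2-yl gives a number 9 percentage points higher from compound 1 to compound 3 (within the scatter), so the three groups at this position, bromo and the two aromatic rings, all lie within the scatter of one another. Nothing at hand explains these numbers.

The compounds shown leave open whether any group on this carbon can move the number beyond the scatter. An amine, a carboxylic acid or a longer alkyl chain at this position would test that, as the three groups shown include none of these.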